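Carboxy in place of chloro on the aroyl ring of compound 3

The source may report more compounds than this note shows. Statements on the series, on what has been measured and on what is new or still open speak of the compounds shown alone.

In a functional assay on DU-145 cells (Homo sapiens) for inhibition, read by trypan blue exclusion, with a stated time of 96 h (on this read-out higher numbers stand for weaker inhibition of growth and lower numbers for stronger inhibition of growth), compound 3 `CN(C)c1ccc(/C=C(/SCc2ccc(F)cc2)C(=O)c2ccc(Cl)cc2)cc1` gives 50000 nM. Compound 1 `CN(C)c1ccc(/C=C(/SCc2ccc(F)cc2)C(=O)c2ccc(Br)cc2)cc1` gives 50000 nM in this assay, and the step of no change at the digits printed from compound 1 to compound 3 (within the scatter). Compound 3 therefore stands level with compound 1 at the digits shown; no ordering between them is claimed. For the measured compounds named here, compound 2 `CN(C)c1ccc(/C=C(\C(=O)c2ccc(C(=O)O)cc2)S(=O)(=O)Cc2ccc(Cl)cc2)cc1` gives > 100000 nM in this assay, which is a limit of the assay and not a number; it is the one value of the three that sits at the limit of > 100000 nM in this assay, at which 1 of the 3 values shown sits.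

Compound 4 `CN(C)c1ccc(/C=C(/SCc2ccc(F)cc2)C(=O)c2ccc(C(=O)O)cc2)cc1` is reached from compound 3 by one change: carboxy in place of chloro on an aromatic carbon. Going by the values given here, the only measured step of a single change, from compound 1 to compound 3, swaps one halogen for another and moved nothing beyond the scatter; no measured step swaps a halogen for a carboxy group. Compound 2, which also carries a carboxy group on that ring, shows only the limit. Compound 4 is therefore expected to shift toward weaker inhibition, with the estimated step of a 2.0-fold higher number from compound 3 to compound 4 (0.30 log units; within the scatter). Compound 4 is estimated at 100000 nM, in a range from 40000 nM to 300000 nM, with a fair chance that only a limit is reported.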

Compound 4, concentration for 50% growth inhibition: 10000 nM
Compound 4: the middle estimate sits 10-fold (1.00 log units) above what was measured; the measured number lies below the stated range.
By their numbers in this assay, from the lowest: compound 4; then compounds 1 and 3 (each within the scatter of the next). At a limit, above all of these: compound 2.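

In this assay, the ring position where chloro and bromo could not be told apart does respond to a carboxy group, with a 5.0-fold lower number from compound 3 to compound 4 (0.70 log units; beyond the scatter) and a 5.0-fold lower number from compound 1 to compound 4 (0.70 log units; beyond the scatter). A carboxy group on this ring does not by itself go with the result for compound 2: with (4-fluorobenzyl)sulfanyl in place of (4-chlorobenzyl)sulfonyl, the series shows an at least 10-fold lower number from compound 2 to compound 4 (1.00 log units; beyond the scatter). That step starts from a value that is a limit of the assay and not a number: the limit of > 100000 nM in this assay, at which 1 of the 4 values shown sits.

The compounds shown leave open whether the stronger inhibition belongs to the carboxy group itself or would also appear with a methyl ester, a primary amide or a tetrazole on this ring. They also leave open how the step between compound 2 and compound 4 divides between the sulfur linkage and the halogen on the benzyl ring.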